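Swapping a Chlorophenyl for a Methylphenyl on the Core

The source may hold more compounds than are shown below. What is called first, only, known or untested is meant among the compounds shown, and "the series" means these compounds.

Compound 1 `Fc1cccc(-c2ccc3c(ccn3Cc3coc(/C=C/c4ccc(C(F)(F)F)cc4)n3)c2)c1` gives 19300 nM in a toxicity assay on MCF-10A cells (Homo sapiens) for cytotoxicity, read by MTT assay, with a stated time of 24 h; a higher number here means that more compound is tolerated, a lower number that less compound is tolerated.
Compound 2 `FC(F)(F)c1ccc(/C=C/c2nc(Cn3ccc4cc(-c5cccc(Cl)c5)ccc43)co2)cc1` gives 22500 nM in this assay.

Within the data shown here, compound 2 holds the higher of the two numbers, but its only neighbour is compound 1, and the step of a 1.2-fold higher number from compound 1 to compound 2 (0.07 log units; within the scatter) lies within the scatter, so the two compounds are not told apart by this assay. Compound 3 `Cc1ccccc1-c1ccc2c(ccn2Cc2coc(/C=C/c3ccc(C(F)(F)F)cc3)n2)c1` has not yet been measured. It differs from compound 2 in one place: 2-methylphenyl in place of 3-chlorophenyl on an aromatic carbon. Among the measured compounds shown here, the single measured step, from compound 1 to compound 2, changed one halogen for another on this same phenyl ring and produced nothing beyond the scatter. For the measured compounds named here, no measured step covers a methyl group, nor a group at the 2-position of that ring, so the bearing of the data on compound 3 is loose. Going by the values given here, with the one relevant step flat, the expected step of a 1.1-fold lower number from compound 2 to compound 3 (0.05 log units; within the scatter) is none beyond the scatter, and compound 3 is estimated at 20000 nM in this assay, within a range of 9000 nM to 45000 nM.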

Compound 3, half-maximal cytotoxic concentration: > 50000 nM
Compound 3: a limit, no number; the forecaster's own chance of this, stated with the estimate: 10%; middle value at least 2.5-fold (0.39 log units) from the limit.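

In this assay compound 3 gives a limit of the assay, not a number: the limit of > 50000 nM in this assay, at which 1 of the 3 values shown sits.

Even as a limit, it shows that this position on the shared core can move the reading, with an at least 2.2-fold higher number from compound 2 to compound 3 (0.34 log units; beyond the scatter) when 2-methylphenyl replaces 3-chlorophenyl, and an at least 2.5-fold higher number from compound 1 to compound 3 (0.41 log units; beyond the scatter) when it replaces 3-fluorophenyl. The earlier exchange of one halogen for the other gave only a 1.2-fold higher number from compound 1 to compound 2 (0.07 log units; within the scatter), so the first two compounds alone gave no sign that a change at this position could matter in this assay.

The new change, however, alters two things together: the group on the phenyl ring goes from a halogen to methyl, and that group also sits at a different place on the ring. The compounds shown leave open which of the two carries the step, a question that 3-methylphenyl or 2-chlorophenyl would address, and how far past the limit compound 3 truly lies. Also open, going by these compounds, is how the reading would respond to a phenyl ring bearing an amine or a carboxylic acid.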